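Swapping the ring on the nitrogen once more

The source may report more compounds than this note shows. Statements on the series, on what has been measured and on what is new or still open speak of the compounds shown alone.

Of the compounds shown here, two have been measured in an ADME assay on RAW264.7 cells (Mus musculus) for cytotoxicity, read by MTT assay, with a stated time of 48 h, tested at 50 uM; on this read-out higher numbers stand for more inhibition at the one concentration tested (going by the name of the read-out) and lower numbers for less inhibition. Compound 1 `N=C1S/C(=C\c2ccc(OCc3ccccc3)cc2)C(=O)N1c1ccc([N+](=O)[O-])cc1` gives 17.3%, and compound 2 `Cc1cccc(N2C(=N)S/C(=C\c3ccc(OCc4ccccc4)cc3)C2=O)n1` gives 25.1%. Compound 2 and compound 1 sit within the usual scatter of each other, so on these two numbers no real difference can be read between them.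

Going by the values given here, the only measured step touching the position of interest is a number 7.8 percentage points higher from compound 1 to compound 2 (within the scatter). There the group on the amide-type nitrogen in the ring was exchanged, and the read-out did not move beyond the scatter.

Compound 3 `Cc1cccc(C)c1N1C(=N)S/C(=C\c2ccc(OCc3ccccc3)cc2)C1=O` differs from compound 2 in the same place: 2,6-dimethylphenyl in place of 6-methylpyridin-2-yl on an amide-type nitrogen in a ring. Among the compounds with values here, since the one measured exchange at this position left the read-out essentially unchanged, the expectation for this further exchange is no step beyond the scatter in this assay, with a step of a number 1.1 percentage points lower from compound 2 to compound 3 (within the scatter) expected from compound 2 to compound 3. Within the data shown here, with only one related step available, the range is wide. Compound 3 is therefore estimated at 24%, between 10% and 38%.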

Compound 3, a percentage reported as inhibition, at one concentration (the size of the read-out at that concentration, not a potency): 38.7%
Beside the measured number, compound 3's estimate is 14.7 percentage points below it, outside the stated range (above it).
By their numbers in this assay, from the lowest: compounds 1 and 2 (each within the scatter of the next); then compound 3.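

Going by these compounds alone, the ring on the amide-type nitrogen can shift this read-out after all: in this assay, 2,6-dimethylphenyl in place of 6-methylpyridin-2-yl gives a number 13.6 percentage points higher from compound 2 to compound 3 (beyond the scatter), and 2,6-dimethylphenyl in place of 4-nitrophenyl gives a number 21.4 percentage points higher from compound 1 to compound 3 (beyond the scatter), so these are the first steps at this position to clear the scatter. The exchange from compound 2 to compound 3 changes more than one feature at once, since the entering ring is of carbon only and has no hydrogen-bond acceptor, whereas the leaving ring has one nitrogen and one acceptor, and the entering group also has two methyl groups where the leaving group has one, so these two compounds cannot show which feature goes with the higher number. No measured evidence is at hand to explain the step.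

As far as these compounds go, it remains open whether both methyl groups of 2,6-dimethylphenyl are needed for the higher number, and what a plain phenyl ring would give on this nitrogen. A phenyl ring carrying an amine or a carboxylic acid would test how far the read-out at this position can move in either direction.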